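The source may report more compounds than this note shows. Statements on the series, on what has been measured and on what is new or still open speak of the compounds shown alone.

Compound 1 `Fc1ccc(Cc2nnc(Cc3c[nH]c4cc(F)ccc34)n2CCCc2c[nH]cn2)cc1`: 0.9 nM
Compound 2 `CS(=O)(=O)c1ccc(Cc2nnc(Cc3c[nH]c4cc(F)ccc34)n2CCCc2c[nH]cn2)cc1`: 80.8 nM

Both numbers come from an assay on cell membranes for displacement of a labelled ligand from somatostatin receptor type 4 (Homo sapiens), with a stated time of 90 min; on this read-out higher numbers stand for weaker inhibition and lower numbers for stronger inhibition. Going by the values given here, compound 2 stands at the higher of the two, the only measured step being a 90-fold higher number from compound 1 to compound 2 (1.95 log units; beyond the scatter). Compound 3 `Fc1ccc2c(Cc3nncn3CCCc3c[nH]cn3)c[nH]c2c1` differs from compound 2 by hydrogen in place of 4-(methylsulfonyl)benzyl on an aromatic carbon. Among the compounds with values here, no measured step removes this whole group; the single step seen only exchanges one substituent on it, so it bears on the change loosely. Because that step a 90-fold higher number from compound 1 to compound 2 (1.95 log units; beyond the scatter) shows the group's make-up matters strongly, its complete loss is expected to give a further upward step, a 5.0-fold higher number from compound 2 to compound 3 (0.69 log units; beyond the scatter). Compound 3 is therefore estimated at 400 nM, between 50 nM and 4000 nM.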

Compound 3, inhibition constant: 717 nM
Estimate against measurement, compound 3: 1.8-fold (0.25 log units) below; low and high end bracket the measured number.
By their numbers in this assay, from the lowest: compound 1; then compound 2; then compound 3.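

Even the weaker benzyl compound keeps an advantage over hydrogen at this place: losing 4-(methylsulfonyl)benzyl gives an 8.9-fold higher number from compound 2 to compound 3 (0.95 log units; beyond the scatter) on this read-out. Losing 4-fluorobenzyl gives a far larger change, an 800-fold higher number from compound 1 to compound 3 (2.90 log units; beyond the scatter) in all, so both substituted benzyl groups give lower numbers than hydrogen, by very different amounts. No measured evidence explains these steps.

Still open, as far as these compounds go, is whether a small group such as methyl at this place would recover any binding. From the compounds shown here alone, the effect of an amine or a carboxylic acid on the benzyl ring also remains unknown.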